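Chromenone series: halogenated phenyl carbamates in this assay

This account rests on a few compounds, and the source may have more. Where it says the series, first, only, none or still open, it means among the compounds named here.

Measured so far:
compound 1, `CC(C)=CCC1Cc2c(OCCCNC(=O)c3cccs3)cc(=O)n(CCCO)c2CC1(C)C`, 5.6%
compound 2, `CC(C)=CCC1Cc2c(OC(=O)Nc3ccc(F)c(F)c3)cc(=O)n(CCCO)c2CC1(C)C`, 0%

In a functional assay on PANC-1 cells (Homo sapiens) for inhibition, read by MTT assay, with a stated time of 24 h, tested at 10 uM (on this read-out lower numbers stand for less inhibition and higher numbers for more inhibition at the one concentration tested (going by the name of the read-out)), compound 1 gives 5.6% and compound 2 gives 0%. Neither number is separated from the other: the step of a number 5.6 percentage points lower from compound 1 to compound 2 (within the scatter) is within the scatter, so compound 2 is not distinguishable from compound 1 on these two numbers, and both sit at the low end of what the read-out can show.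

Compound 3, `CC(C)=CCC1Cc2c(OC(=O)Nc3ccc(Cl)cc3)cc(=O)n(CCCO)c2CC1(C)C`, differs from compound 2 by 4-chlorophenyl in place of 3,4-difluorophenyl on an amide-type nitrogen. Among the compounds with values here, no measured step touches the halogen pattern on the phenyl of the carbamate; the only step recorded, from compound 1 to compound 2, concerns the whole substituent on the ring oxygen and was itself within the scatter. With both measured numbers low and no step beyond the scatter anywhere in the series, no change beyond the scatter is expected for compound 3 in this assay, the expected step being a number 4 percentage points higher from compound 2 to compound 3 (within the scatter).

Compound 3 is therefore estimated at 4%, within 0% to 15%.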

Compound 3, a percentage reported as inhibition, at one concentration (the size of the read-out at that concentration, not a potency): 0%
Beside the measured number, compound 3's estimate is 4 percentage points above it; the range from low to high includes it.
By their numbers in this assay, from the lowest: compounds 2, 3 and 1 (each within the scatter of the next).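

In this assay the amide-type nitrogen takes 4-chlorophenyl in place of 3,4-difluorophenyl with no change at the digits printed from compound 2 to compound 3 (within the scatter) and so shows no separation between these two halogenated phenyl groups at this position. Replacing 3-(((thiophen-2-yl)carbonyl)amino)propyl on the oxygen on an aromatic ring with (4-chlorophenyl)carbamoyl gives a number 5.6 percentage points lower from compound 1 to compound 3 (within the scatter) and, like the earlier difluorophenyl carbamate, does not separate the two substituents. No available evidence bears on this result.

Left open is whether any group on the amide-type nitrogen moves this read-out beyond the scatter, for example a phenyl carrying a carboxylic acid or a dimethylamino group. Also open, from the compounds shown here alone, is whether a longer chain ending in an amine, placed on the same oxygen, gives a number clear of the low end seen in these compounds.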